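Moving the bromine around the phenyl ring of compound 3

This account rests on a few compounds, and the source may have more. Where it says the series, first, only, none or still open, it means among the compounds named here.

Three compounds share one core and differ only in the phenyl group attached to it. Compound 1 `Cn1nc(-c2nnc(-c3ccccc3)o2)c2ccccc21` carries a plain phenyl and gives 37500 nM in a functional assay on HepG2 cells (Homo sapiens) for antiproliferative activity, read by MTT assay, with a stated time of 72 h; on this read-out higher numbers stand for weaker inhibition and lower numbers for stronger inhibition. Compound 2 `Cn1nc(-c2nnc(-c3ccc(O)cc3)o2)c2ccccc21` gives 86400 nM, a shift described by a 2.3-fold higher number from compound 1 to compound 2 (0.36 log units; beyond the scatter). Compound 3 `Cn1nc(-c2nnc(-c3ccccc3Br)o2)c2ccccc21` gives 22300 nM, the lowest of the three numbers, although the shift a 1.7-fold lower number from compound 1 to compound 3 (0.23 log units; within the scatter) lies within the scatter, while the step of a 3.9-fold lower number from compound 2 to compound 3 (0.59 log units; beyond the scatter) lies beyond it.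

Compound 4 `Cn1nc(-c2nnc(-c3cccc(Br)c3)o2)c2ccccc21` differs from compound 3 by 3-bromophenyl in place of 2-bromophenyl on an aromatic carbon. Going by the values given here, no measured pair shows what moving the bromine from one ring position to another does; the only step involving bromine, a 1.7-fold lower number from compound 1 to compound 3 (0.23 log units; within the scatter), is the small gain from adding it at all. With so little to go on, the expectation for compound 4 is a step of about a 1.1-fold higher number from compound 3 to compound 4 (0.05 log units; within the scatter), a number close to that of compound 3 and probably within the scatter. Compound 4 is therefore expected to give 25000 nM, within a range from 10000 nM to 60000 nM.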

Compound 4, half-maximal inhibitory concentration: 24500 nM
Compound 4: the middle estimate sits 1.0-fold (0.01 log units) above what was measured; the range from low to high includes it.
By their numbers in this assay, from the lowest: compounds 3, 4 and 1 (each within the scatter of the next); then compound 2.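

Replacing 2-bromophenyl with 3-bromophenyl gives a 1.1-fold higher number from compound 3 to compound 4 (0.04 log units; within the scatter) in this assay, so the two ring positions of the bromine tested here cannot be told apart on this read-out. Compound 4 also cannot be told apart from the plain phenyl of compound 1, with a 1.5-fold lower number from compound 1 to compound 4 (0.18 log units; within the scatter) as the step, so at neither position does bromine give a clear gain over hydrogen. The step of a 3.5-fold lower number from compound 2 to compound 4 (0.55 log units; beyond the scatter) is beyond the scatter, as was the step to compound 3, which leaves compound 2, with its 4-hydroxyphenyl, as the only one of the four that stands apart.

Still open, going by these compounds, is whether a different group on the phenyl ring, such as an amine or a carboxylic acid, would move the number beyond the scatter. No measurement shown offers an explanation for these numbers.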